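Chain on a Ring Nitrogen and Minimum Effective Dose

A few compounds are considered here, and "the series" means these few. Any claim that something is new, unique, unknown or untested is made for them only; others in the source may bear on it.

Measured compounds:
Compound 1, `Cc1nn(C)c2c1C(c1ccccc1Cl)=NCCN2`, gives 2.5 mg/kg.
Compound 2, `Cc1nn(C)c2c1C(c1ccccc1Cl)=NCCN2CCCN(C)C`, is reported only as a limit, > 10 mg/kg.
Compound 3, `Cc1cccc(C2=NCCNc3c2c(C)nn3C)c1`, gives 2.5 mg/kg.

In a functional assay on the whole organism for positive allosteric modulation, with Rattus norvegicus as the target (a lower number here means that less compound is needed, a higher number that more compound is needed for the effect), compound 1 gives 2.5 mg/kg. Compound 2 carries the change 3-(dimethylamino)propyl in place of hydrogen on a nitrogen on an aromatic ring in a ring and its result is a limit of the assay, > 10 mg/kg, as noted in the limit of > 10 mg/kg in this assay, at which 1 of the 3 values shown sits. The step is an at least 4.0-fold higher number from compound 1 to compound 2 (0.60 log units; beyond the scatter). Compound 3 gives 2.5 mg/kg in this assay; the difference between its core and that of compound 1 is not broken down here. Compound 4, `Cc1cccc(C2=NCCN(CCCN(C)C)c3c2c(C)nn3C)c1`, differs from compound 3 by 3-(dimethylamino)propyl in place of hydrogen on a nitrogen on an aromatic ring in a ring, the same kind of change, the place differing only in the ring atom bearing a 3-methylphenyl group rather than a 2-chlorophenyl group. The expected step is a 4.8-fold higher number from compound 3 to compound 4 (0.68 log units; beyond the scatter), resting on the step of an at least 4.0-fold higher number from compound 1 to compound 2 (0.60 log units; beyond the scatter) seen for compound 1. Compound 4 is therefore estimated at 12 mg/kg, likely itself a limit.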

Compound 4, minimum effective dose: > 10 mg/kg
Compound 4: only a limit was reported; the forecaster's own chance of this, stated with the estimate: 60%; the middle value is on the limit's open side.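

In this assay, the same change, 3-(dimethylamino)propyl in place of hydrogen on the nitrogen, gives an at least 4.0-fold higher number from compound 3 to compound 4 (0.60 log units; beyond the scatter), so the rise in required dose seen on the core of compound 1 also appears on the core of compound 3. This shows the direction carrying over between the two cores, but not that the size is the same, since both steps rest on limits: the same change on two cores in this assay, an at least 4.0-fold higher number (0.60 log units; beyond the scatter) from compound 1 to compound 2 and an at least 4.0-fold higher number (0.60 log units; beyond the scatter) from compound 3 to compound 4; the limit leaves it open whether they differ The step between the two chain-bearing compounds, 3-methylphenyl in place of 2-chlorophenyl, cannot be read, as both values are limits: the limit of > 10 mg/kg in this assay, at which 2 of the 4 values shown sit.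

The compounds shown leave open whether the propyl chain or its dimethylamino end accounts for the step. A simple methyl, a shorter chain or a chain ending in a carboxylic acid on that nitrogen would bear on this.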